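Ring Size on the Triazole Nitrogen: Compound 2 to Compound 4

This account rests on a few compounds, and the source may have more. Where it says the series, first, only, none or still open, it means among the compounds named here.

Compound 2 `CC(C)CCn1nc(C(=O)N[C@H]2COc3ccccc3N(C)C2=S)nc1Cc1ccccc1` belongs to a small set of three amides built on a shared core, differing only in the group carried on an aromatic nitrogen. In a functional assay on HT-29 cells (Homo sapiens) for inhibition, read by luminescence and CellTiter-Glo, with a stated time of 24 h (on this read-out lower numbers stand for an effect already at smaller amounts and higher numbers for an effect only at larger amounts of compound), compound 2 gives 3640 nM, the second highest of the three numbers. Its closest neighbour is compound 3 `CN1C(=S)[C@@H](NC(=O)c2nc(Cc3ccccc3)n(C3CCCCC3)n2)COc2ccccc21`, which in this assay gives 4000 nM; the two lie within the scatter of one another, as seen in a 1.1-fold higher number from compound 2 to compound 3 (0.04 log units; within the scatter). Compound 1 `CCCCCn1nc(C(=O)N[C@H]2COc3ccccc3N(C)C2=S)nc1Cc1ccccc1` gives 805 nM, and the step of a 4.5-fold higher number from compound 1 to compound 2 (0.66 log units; beyond the scatter) is modest but beyond the scatter, as is a 5.0-fold higher number from compound 1 to compound 3 (0.70 log units; beyond the scatter).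

Compound 4 `CN1C(=S)[C@@H](NC(=O)c2nc(Cc3ccccc3)n(C3CCCCCC3)n2)COc2ccccc21` has not yet been measured. It differs from compound 2 by cycloheptyl in place of isopentyl on an aromatic nitrogen. The step that bears most directly on this change is a 1.1-fold higher number from compound 2 to compound 3 (0.04 log units; within the scatter), where a cycloalkyl ring replacing the isopentyl chain moved the number by no more than the scatter. Among the measured compounds shown here, a seven-membered ring is one carbon larger, and nothing among the measured compounds shows what that extra carbon does. For compound 4 the expected step is therefore a 1.2-fold higher number from compound 2 to compound 4 (0.09 log units; within the scatter), none beyond the scatter, with a wide range. Compound 4 is estimated at 4500 nM, between 1500 nM and 14000 nM.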

Compound 4, half-maximal effective concentration: 5530 nM
Beside the measured number, compound 4's estimate is 1.2-fold (0.09 log units) below it; the measured number falls inside the stated range.
By their numbers in this assay, from the lowest: compound 1; then compounds 2, 3 and 4 (each within the scatter of the next).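

In this assay, a seven-membered non-aromatic ring of carbon only on the aromatic nitrogen cannot be told apart from the isopentyl chain, with a 1.5-fold higher number from compound 2 to compound 4 (0.18 log units; within the scatter), or from the cyclohexyl ring, with a 1.4-fold higher number from compound 3 to compound 4 (0.14 log units; within the scatter). Among the compounds shown here, the extra ring carbon, on which the earlier compounds were silent, thus leaves the number within the scatter. For the compounds shown here, the pentyl group of compound 1 remains the only group here that stands apart from the others, and the widest step in the set is modest, with a 6.9-fold higher number from compound 1 to compound 4 (0.84 log units; beyond the scatter).

Nothing measured here explains why the pentyl chain stands apart from the isopentyl chain and the two rings. Going by these compounds, whether a longer straight chain such as hexyl would extend the lead of compound 1, or a smaller ring such as cyclopentyl would fall with the larger rings, remains open.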